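Does a Longer Chain Still Help? Compound 4

A few compounds are considered here, and "the series" means these few. Any claim that something is new, unique, unknown or untested is made for them only; others in the source may bear on it.

Measured in a functional assay on MCF7 cells (Homo sapiens) for antiproliferative activity, read by MTT assay, with a stated time of 48 h; a higher number here means a weaker inhibitor, a lower number a stronger inhibitor:
- compound 1 `CCCCCCCn1cc(COC[C@@H]2OC[C@H](N)[C@@H]2O)nn1`: > 128000 nM (a limit of the assay, not a number)
- compound 2 `CCCCCCCCn1cc(COC[C@@H]2OC[C@H](N)[C@@H]2O)nn1`: 28100 nM
- compound 3 `CCCCCCCCCCCCn1cc(COC[C@@H]2OC[C@H](N)[C@@H]2O)nn1`: 2210 nM

Among the measured compounds shown here, compound 3 holds the lowest number so far, and its nearest neighbour is compound 2, with a 13-fold lower number from compound 2 to compound 3 (1.10 log units; beyond the scatter). Among these three compounds, the longer the chain on the shared core, the lower the number, and none goes against this. The earlier steps shown here were an at least 4.5-fold lower number from compound 1 to compound 2 (0.65 log units; beyond the scatter) and an at least 57-fold lower number from compound 1 to compound 3 (1.76 log units; beyond the scatter).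

The next compound, compound 4 `CCCCCCCCCCCCCCn1cc(COC[C@@H]2OC[C@H](N)[C@@H]2O)nn1`, extends the chain further: ethyl in place of hydrogen on a saturated chain carbon, ten or more bonds along the chain from an aromatic nitrogen. The closest guide is a 13-fold lower number from compound 2 to compound 3 (1.10 log units; beyond the scatter), where butyl entered, a larger addition than the ethyl entering here. For the measured compounds named here, no measured compound has a chain longer than that of compound 3, so the trend may flatten. In this assay, a small expected change towards a lower number is therefore estimated, possibly not beyond the usual scatter: a 1.8-fold lower number from compound 3 to compound 4 (0.27 log units; within the scatter). The estimated value for compound 4 is 1200 nM, with an expected range of 450 nM to 3500 nM.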

Compound 4, half-maximal inhibitory concentration: 1850 nM
Beside the measured number, compound 4's estimate is 1.5-fold (0.19 log units) below it, within the range that was stated.
By their numbers in this assay, from the lowest: compounds 4 and 3 (each within the scatter of the next); then compound 2. At a limit, above all of these: compound 1.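

In this assay, the added ethyl gives a much smaller step than those seen along the shorter chains (a 1.2-fold lower number from compound 3 to compound 4 (0.08 log units; within the scatter)), so the steep gain in lengthening the chain does not carry on at this position. The longer chain keeps the gain already made over the shorter ones (a 15-fold lower number from compound 2 to compound 4 (1.18 log units; beyond the scatter)), and the step from the shortest chain is larger still (an at least 69-fold lower number from compound 1 to compound 4 (1.84 log units; beyond the scatter)). That last step is only a lower bound, as compound 1 stands at a limit of the assay and not at a number: the limit of > 128000 nM in this assay, at which 1 of the 4 values shown sits.

Going by these compounds, it remains open whether a longer chain would hold this level or lose it, so the flat stretch may or may not be a true plateau. On these data alone, it is also open whether a chain ending in a hydroxyl or a carboxylic acid would behave like these plain carbon chains.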